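A few compounds are considered here, and "the series" means these few. Any claim that something is new, unique, unknown or untested is made for them only; others in the source may bear on it.

Compound 1 `CCO[C@H]1C[C@@H](c2coc3ccc(Br)cc3c2=O)N(c2ccccc2)O1` was examined in a functional assay on Caco-2 cells (Homo sapiens) for inhibition, read by sulforhodamine B assay, with a stated time of 48 h; on this read-out higher numbers stand for weaker inhibition and lower numbers for stronger inhibition. In that test compound 1 reaches only the assay limit, > 60000 nM. Compound 2 `COC(=O)[C@H]1C[C@@H](c2coc3ccc(Cl)cc3c2=O)N(c2ccccc2)O1` likewise stops at the limit, > 60000 nM. Compound 3 `O=C1[C@H]2[C@H](ON(c3ccccc3)[C@@H]2c2coc3ccc(F)cc3c2=O)C(=O)N1c1ccccc1` also gives no more than the limit, > 60000 nM. Among the measured compounds shown here, all three results thus sit at the limit of > 60000 nM in this assay, at which 3 of the 3 values shown sit, and since no two of the measured compounds differ from each other in a single place, there is no measured step on the shared core from which to gauge how a small change moves the read-out. Compound 4 `CCO[C@H]1C[C@@H](c2coc3ccc(C)cc3c2=O)N(c2ccccc2)O1` has not yet been measured. It differs from compound 1 by methyl in place of bromo on an aromatic carbon. Because compound 1 stands at its limit > 60000 nM in this assay, the expected step that the limit leaves unreadable from compound 1 to compound 4 is taken to be flat, with no change beyond the scatter. Compound 4 is therefore estimated at 80000 nM, with a range from 30000 nM to 300000 nM, and it would most likely again be reported only as a limit.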

Compound 4, half-maximal inhibitory concentration: 31000 nM
Estimate against measurement, compound 4: 2.6-fold (0.41 log units) above; low and high end bracket the measured number.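

In this assay compound 4 gives a measured number, 31000 nM, and it is the only compound shown that does so. The rest stay at a limit of the assay: the limit of > 60000 nM in this assay, at which 3 of the 4 values shown sit. Methyl in place of bromo on this aromatic carbon therefore gives the first readable, though only bounded, step on this core, an at least 1.9-fold lower number from compound 1 to compound 4 (0.28 log units; that floor lies within the scatter), and the true size of the step remains hidden behind the limit of compound 1.

The compounds shown leave open how a longer chain, a methoxy group or an amine would read on this same aromatic carbon. They also leave open whether methyl in place of chloro on compound 2, or in place of fluoro on compound 3, would bring those compounds off the limit.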